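Replacing the aminoaryl amide of compound 1 with a hydroxy group

The source may hold more compounds than are shown below. What is called first, only, known or untested is meant among the compounds shown, and "the series" means these compounds.

Compound 1 `Nc1cc2ccccc2cc1NC(=O)c1ccc(CNc2nccc(-c3cccnc3)n2)cc1` is one of three related compounds tested in an assay for inhibition of histone deacetylase 8 (Homo sapiens), read by fluorescence, with stated times of 15 min and 60 min; a higher number here means a weaker inhibitor, a lower number a stronger inhibitor. Compound 1 gives only a limit, > 20000 nM, which is the limit of > 20000 nM in this assay, at which 1 of the 3 values shown sits. Compound 2 `CC(=O)N1C(NCc2ccc(C(=O)Nc3ccccc3N)cc2)=NC(=O)C1Cc1ccccc1` gives 22700 nM in this assay, and compound 3 `CC(C)(C)OC(=O)N1C(NCc2ccc(C(=O)Nc3ccccc3N)cc2)=NC(=O)C1Cc1c[nH]c2ccccc12` gives 27200 nM; all three sit at the weak end of this assay. Compound 4 `O=C(NO)c1ccc(CNc2nccc(-c3cccnc3)n2)cc1` has not yet been measured; it differs from compound 1 by one oxygen atom in place of a group of 11 heavy atoms (10 carbon, 1 nitrogen; 2 six-membered aromatic rings of carbon only), on an amide-type nitrogen. Going by the values given here, no step between two measured compounds is available here, so the effect of this change can only be anticipated. In this assay compound 4 is expected to give 400 nM, with a range from 60 nM to 3000 nM. The estimated step of an at least 50-fold lower number from compound 1 to compound 4 (1.69 log units; beyond the scatter) is expected to be large and toward stronger inhibition, far beyond the usual scatter.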

Compound 4, half-maximal inhibitory concentration: 410 nM
The estimate for compound 4 lay 1.0-fold (0.01 log units) below the measured number, and the stated range covers the measured number.
By their numbers in this assay, from the lowest: compound 4; then compounds 2 and 3 (each within the scatter of the next).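

In this assay, a hydroxy group on the amide-type nitrogen, in place of the group of 11 heavy atoms, gives an at least 48-fold lower number from compound 1 to compound 4 (1.68 log units; beyond the scatter). This is the first step shown at this position, and it shows that the change can move a compound far from the weak end of the assay. Compound 1 gives a limit and not a number, so the step is only a bound: the limit of > 20000 nM in this assay, at which 1 of the 4 values shown sits.

Going by these compounds, whether a methoxy group or a plain amine on this nitrogen would give a similar number stays open. So does whether the same hydroxy change would lower the numbers of compound 2 and compound 3.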